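Pyrimidinyl-piperazine quinazolines: alkoxy against methyl on the pyrimidine

The compounds below may be only part of what the source reports. "The series", "measured", "known", "first", "only" and "open" are said of these compounds alone.

Measured so far:
Compound 1 `CCCOc1ccnc(N2CCN(c3nc(N)c4cc(OC)c(OC)cc4n3)CC2)n1`: 0.32 nM
Compound 2 `COc1cc2nc(N3CCN(c4nccc(C)n4)CC3)nc(N)c2cc1OC`: 0.92 nM

In an assay on brain for binding affinity to Adrenergic receptor alpha-1 (Rattus norvegicus) (a higher number here means a weaker inhibitor, a lower number a stronger inhibitor), compound 2 gives 0.92 nM, the higher of the two numbers measured, while compound 1 gives 0.32 nM. Among the compounds with values here, the single measured step, a 2.9-fold higher number from compound 1 to compound 2 (0.46 log units; beyond the scatter), shows that trading an alkoxy group on the pyrimidine for a methyl raised the number by a modest but real margin.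

Compound 3 `COc1cc2nc(N3CCN(c4cc(OC(C)C)ncn4)CC3)nc(N)c2cc1OC` has not yet been measured. It differs from compound 2 by 6-isopropoxypyrimidin-4-yl in place of 4-methylpyrimidin-2-yl on an amine nitrogen in a ring. This change brings an alkoxy group back onto the pyrimidine, though on a ring drawn with a different attachment and with a branched chain, so the step from compound 1 to compound 2 bears on it only loosely. Compound 3 is therefore expected to fall somewhat below compound 2 in this assay, a step of roughly a 2.0-fold lower number from compound 2 to compound 3 (0.31 log units; beyond the scatter), giving an estimate of 0.45 nM with a range from 0.15 nM to 1.3 nM.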

Compound 3, inhibition constant: 0.18 nM
The estimate for compound 3 lay 2.5-fold (0.40 log units) above the measured number, within the range that was stated.
By their numbers in this assay, from the lowest: compounds 3 and 1 (each within the scatter of the next); then compound 2.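

In this assay, placing 6-isopropoxypyrimidin-4-yl on the amine nitrogen in a ring instead of 4-methylpyrimidin-2-yl gave a 5.1-fold lower number from compound 2 to compound 3 (0.71 log units; beyond the scatter), so this position accepts a branched alkoxy pyrimidine with a different attachment. Against compound 1, the change gave a 1.8-fold lower number from compound 1 to compound 3 (0.25 log units; within the scatter), which leaves 6-isopropoxypyrimidin-4-yl and 4-propoxypyrimidin-2-yl indistinguishable in this assay, while each alkoxy compound stands beyond the scatter from the methyl compound 2. Nothing available here accounts for these differences.

From the compounds shown here alone, the step from compound 2 to compound 3 changes the substituent and the ring attachment together, so the share of each remains open. Also open, going by these compounds, is whether 6-methylpyrimidin-4-yl, or an amine or a butoxy chain on the pyrimidine, would give a similar number.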